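The source may hold more compounds than are shown below. What is called first, only, known or untested is meant among the compounds shown, and "the series" means these compounds.

Within the data shown here, in a functional assay on P388 cells (Mus musculus) (a lower number here means a stronger inhibitor, a higher number a weaker inhibitor), only two compounds have been measured so far. Compound 1 `O=C(/C=C/c1ccc(Br)cc1)Oc1ccc(/C=C2\CCCCC2=O)cc1` reads > 50000 nM, which is a limit of the assay and not a number. Among the measured compounds shown here, compound 2 `COc1ccc(/C=C/C(=O)Oc2ccc(/C=C3\CCCC(CN(C)C)C3=O)cc2)cc1` gives 2410 nM, the only actual number available, and no step between measured compounds exists to guide the next reading. Compound 3 `CN(C)CC1CCC/C(=C\c2ccc(OC(=O)/C=C/c3ccc(Br)cc3)cc2)C1=O` departs from compound 2 through bromo in place of methoxy on an aromatic carbon, para to a large group, so that 4-methoxyphenyl becomes 4-bromophenyl. For the measured compounds named here, no measurement yet shows what this exchange does, so no shift beyond the scatter is expected in this assay, and the reading of compound 2 at 2410 nM serves as the anchor. The estimated change is a 1.2-fold lower number from compound 2 to compound 3 (0.08 log units; within the scatter), too small to favour a direction. Compound 3 is expected at about 2000 nM, within an estimated range of 600 nM to 7000 nM.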

Compound 3, half-maximal inhibitory concentration: 4030 nM
For compound 3 the middle estimate is 2.0-fold (0.30 log units) below the measured one; measured number inside the range.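

In this assay, bromo in place of methoxy on an aromatic carbon, para to a large group, gives a 1.7-fold higher number from compound 2 to compound 3 (0.22 log units; within the scatter), so the 4-methoxyphenyl and 4-bromophenyl compounds cannot be told apart at this position. Among these compounds, with the 4-bromophenyl kept, (dimethylamino)methyl in place of hydrogen on a saturated ring carbon gives an at least 12-fold lower number from compound 1 to compound 3 (1.09 log units; beyond the scatter), the only step here beyond the scatter, which places the large difference at that ring carbon and not on the aromatic ring. The reading of compound 1 is a limit of the assay and not a number: the limit of > 50000 nM in this assay, at which 1 of the 3 values shown sits.

From the compounds shown here alone, whether an amine or a carboxylic acid on that aromatic carbon would read like bromo and methoxy remains open. So does whether a longer chain carrying the dimethylamino group would match (dimethylamino)methyl on the saturated ring carbon.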